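Changing the Ring on the Carbonyl Carbon: Compound 4

A few compounds are considered here, and "the series" means these few. Any claim that something is new, unique, unknown or untested is made for them only; others in the source may bear on it.

Compound 1 `COc1cc(-c2cc(/C=C/C(=O)c3ccc(N)cc3)[nH]n2)cc(OC)c1OC` gives 92% in a functional assay on SF-539 cells (Homo sapiens) for cytotoxicity, read by sulforhodamine B assay, with a stated time of 48 h, tested at 0.01 uM; on this read-out higher numbers stand for a weaker effect at the one concentration tested and lower numbers for a stronger effect.
Compound 2 `COc1cc(-c2cc(/C=C/C(=O)c3ccc(Cl)c(Cl)c3)[nH]n2)cc(OC)c1OC` gives 93% in this assay.
Compound 3 `COc1ccc(C(=O)/C=C/c2cc(-c3cc(OC)c(OC)c(OC)c3)n[nH]2)cc1` gives 97% in this assay.

All three measured compounds share a core and differ only in the ring attached to the carbonyl carbon, and all three show only a weak effect at the single concentration tested. Compound 3 has the highest of the three numbers, but its neighbours sit close: a number 4 percentage points higher from compound 2 to compound 3 (within the scatter) and a number 5 percentage points higher from compound 1 to compound 3 (within the scatter), and a number 1 percentage points higher from compound 1 to compound 2 (within the scatter). None of these steps leaves the scatter.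

Compound 4 `COc1cc(-c2cc(/C=C/C(=O)c3ccc(F)c(F)c3)[nH]n2)cc(OC)c1OC` is not yet measured. Its change from compound 3 is 3,4-difluorophenyl in place of 4-methoxyphenyl on a carbonyl carbon. The closest guide is the step between compound 2 and compound 3, where a dihalogenated ring and the methoxy-bearing ring gave numbers within the scatter of each other. Compound 4 is therefore expected to give 94% in this assay, within a range of 85% to 100%. The estimated step of a number 3 percentage points lower from compound 3 to compound 4 (within the scatter) is expected to stay within the scatter.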

Compound 4, a percentage reported as activity, at one concentration (the size of the read-out at that concentration, not a potency): 100%
Estimate against measurement, compound 4: 6 percentage points below; measured number inside the range.
By their numbers in this assay, from the lowest: compounds 1, 2, 3 and 4 (each within the scatter of the next).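

Placing 3,4-difluorophenyl on the carbonyl carbon gives a number 3 percentage points higher from compound 3 to compound 4 (within the scatter) in this assay, alongside a number 7 percentage points higher from compound 2 to compound 4 (within the scatter) and a number 8 percentage points higher from compound 1 to compound 4 (within the scatter) as the other two comparisons. For the compounds shown here, the comparison with compound 2 is new in keeping the substitution pattern on the ring while exchanging its two chlorines for two fluorines, and the comparison with compound 3 replaces a ring with one hydrogen-bond acceptor by one with none, yet no step among the four compounds leaves the scatter. Nothing measured here speaks to what lies behind these numbers.

Every ring at this position in the compounds shown is a six-membered aromatic ring of carbon only. From the compounds shown here alone, whether a carboxylic acid on that ring, or a longer chain in its place, would give a clearly lower number remains open.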